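Swapping Methyl for Methoxy in Compound 3

A few compounds are considered here, and "the series" means these few. Any claim that something is new, unique, unknown or untested is made for them only; others in the source may bear on it.

In a functional assay on MOLT-4 cells (Homo sapiens) for antiproliferative activity, with a stated time of 48 h (a higher number here means a weaker inhibitor, a lower number a stronger inhibitor), compound 3 (`Cc1ccc(C(=O)/C=C/c2ccc(N)cc2)cc1`) gives 12000 nM and compound 2 (`Nc1ccc(/C=C/C(=O)c2ccc(Cl)cc2)cc1`) gives 7800 nM as its number, so these two stand level within the scatter. Among the measured compounds shown here, compound 1 (`C=C(Br)C(=O)Nc1ccc(/C=C/C(=O)c2ccc(OC)cc2)cc1`) gives a lower number at 1300 nM but no measured step links it to compound 4. Compound 4 (`COc1ccc(C(=O)/C=C/c2ccc(N)cc2)cc1`) carries methoxy in place of methyl on an aromatic carbon. For the measured compounds named here, the one measured step that bears on this is a 1.5-fold higher number from compound 2 to compound 3 (0.19 log units; within the scatter) which also swaps a group on an aromatic carbon. One small step is thin evidence, so no change beyond the scatter is expected in this assay here. The expected step is a 1.2-fold lower number from compound 3 to compound 4 (0.08 log units; within the scatter) and no larger. For compound 4 the estimated value is 10000 nM with an expected range from 5000 nM to 20000 nM in this measurement.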

Compound 4, half-maximal inhibitory concentration: 19000 nM
Estimate against measurement, compound 4: 1.9-fold (0.28 log units) below, within the range that was stated.
By their numbers in this assay, from the lowest: compound 1; then compounds 2, 3 and 4 (each within the scatter of the next, the first and the last beyond it).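

In this assay, methoxy on this aromatic carbon stands level with methyl, at a 1.6-fold higher number from compound 3 to compound 4 (0.20 log units; within the scatter), yet it parts modestly from chloro, at a 2.4-fold higher number from compound 2 to compound 4 (0.39 log units; beyond the scatter). The much larger step lies on the nitrogen: with methoxy in both compounds, hydrogen in place of (1-bromoethenyl)carbonyl gives a 15-fold higher number from compound 1 to compound 4 (1.16 log units; beyond the scatter). No measurement shown here explains either finding.

As far as these compounds go, whether a hydroxyl, a fluoro or a longer chain such as ethoxy at this place would stand level with these groups remains open. So does whether a plain acetyl on the nitrogen would keep the lower number of compound 1.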